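This account rests on a few compounds, and the source may have more. Where it says the series, first, only, none or still open, it means among the compounds named here.

Measured so far:
compound 1, `Cc1cccc(Cn2c(CN3CCN(C(=O)C4CCCCC4)CC3)nc3ccccc32)c1`: 31.9%
compound 2, `CC(C)=CCn1c(CN2CCN(C(=O)C3CC3)CC2)nc2ccccc21`: 74.3%

In an assay on isolated protein for inhibition of aldehyde dehydrogenase 1A1 (Homo sapiens), read by spectrophotometry, tested at 10 uM (on this read-out lower numbers stand for less inhibition and higher numbers for more inhibition at the one concentration tested (going by the name of the read-out)), compound 1 gives 31.9%, the lower of the two numbers in hand. Compound 2 gives 74.3% in the same assay, a gap beyond the scatter, but the two compounds differ in more than one place, so no single change can be read from that pair. Compound 3, `CC(=O)N1CCN(Cc2nc3ccccc3n2Cc2cccc(C)c2)CC1`, is not yet measured. It differs from compound 1 in one place: methyl in place of cyclohexyl on a carbonyl carbon. Among the compounds with values here, no measured pair shows this change on its own, so its direction is open; the nearest information is the gap to compound 2, which is not a clean comparison. The step from compound 1 to compound 3 in this assay is expected to be a number 1.9 percentage points lower from compound 1 to compound 3 (within the scatter), not beyond the scatter in either direction. Compound 3 is therefore expected to give 30%, with a range from 10% to 55%.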

Compound 3, a percentage reported as inhibition, at one concentration (the size of the read-out at that concentration, not a potency): 70.3%
Estimate against measurement, compound 3: 40.3 percentage points below; the measured number lies above the stated range.
By their numbers in this assay, from the lowest: compound 1; then compounds 3 and 2 (each within the scatter of the next).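

In this assay the group on this carbonyl carbon matters: with the rest of compound 1 unchanged, the step of a number 38.4 percentage points higher from compound 1 to compound 3 (beyond the scatter) is large. Within the data shown here, this is the first comparison that differs in one place, so the cyclohexylcarbonyl to acetyl change alone is seen to move the read-out beyond the scatter, with the smaller group giving the higher inhibition. Nothing in hand accounts for the size or direction of this step.

On these data alone, with only methyl and cyclohexyl compared on this background, it remains open whether the read-out follows the size of the group, the presence of a ring, or neither; a straight butyl chain, a phenyl or an amine on the same carbonyl carbon would separate these readings. As far as these compounds go, whether the step keeps its size when other parts of the shared core change also remains open.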